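Oxygen into the ring: from compound 3 to compound 4

The compounds below may be only part of what the source reports. "The series", "measured", "known", "first", "only" and "open" are said of these compounds alone.

Compound 1, `Cc1nnn(Cc2ccc(C(F)(F)F)cc2)c1C(=O)N[C@@H](C)c1ccc(C(=O)O)cc1`: > 10000 nM
Compound 2, `CCc1nnn(Cc2ccc(C(F)(F)F)cc2)c1C(=O)N[C@@H](C)c1ccc(C(=O)O)cc1`: > 10000 nM
Compound 3, `C[C@H](NC(=O)c1c(C2=CCCCC2)nnn1Cc1ccc(C(F)(F)F)cc1)c1ccc(C(=O)O)cc1`: 183 nM

Of the compounds shown here, three have been tested in a functional assay on CHO cells for antagonist activity at prostaglandin E2 receptor EP4 subtype (Homo sapiens), read by calcium flux, with a stated time of 15 min; a higher number here means a weaker inhibitor, a lower number a stronger inhibitor. For compound 1 the reading of > 10000 nM is a limit of the assay, not a number. For compound 2 the reading of > 10000 nM is likewise a limit. Within the data shown here, compound 3 gives 183 nM and is the only compound with a true number, so it stands alone as the one measurable inhibitor. The steps of an at least 54-fold lower number from compound 1 to compound 3 (1.73 log units; beyond the scatter) and an at least 54-fold lower number from compound 2 to compound 3 (1.73 log units; beyond the scatter) are both large and beyond the scatter, whereas a step that the two limits leave unreadable from compound 1 to compound 2 cannot be read because both readings sit at the limit (the limit of > 10000 nM in this assay, at which 2 of the 3 values shown sit).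

Compound 4, `C[C@H](NC(=O)c1c(C2=CCOCC2)nnn1Cc1ccc(C(F)(F)F)cc1)c1ccc(C(=O)O)cc1`, is not yet measured. The change is a group of 6 heavy atoms (5 carbon, 1 oxygen; one six-membered non-aromatic ring with 1 hetero atom) in place of a group of 6 heavy atoms (6 carbon; one six-membered non-aromatic ring of carbon only), on an aromatic carbon. Neither measured step speaks directly to this change: the measured steps enlarge a small group into a six-membered ring, while here the ring keeps its size and one carbon becomes an oxygen. Among the measured compounds shown here, with no guiding step, compound 4 is expected to stay close to compound 3, with a 1.6-fold higher number from compound 3 to compound 4 (0.21 log units; within the scatter) as the expected step. The estimate for compound 4 is 300 nM, in the range 90 nM to 1200 nM.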

Compound 4, half-maximal inhibitory concentration: 119 nM
Compound 4: middle estimate off by 2.5-fold (0.40 log units), on the high side, and the stated range covers the measured number.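

Putting an oxygen into the six-membered ring on the aromatic carbon gives a 1.5-fold lower number from compound 3 to compound 4 (0.19 log units; within the scatter), so in this assay this position accepts a ring with a hetero atom and a hydrogen-bond acceptor as well as the all-carbon ring. The large distance from the small groups is therefore not tied to an all-carbon ring, as the oxygen ring also shows an at least 84-fold lower number from compound 2 to compound 4 (1.92 log units; beyond the scatter) and an at least 84-fold lower number from compound 1 to compound 4 (1.92 log units; beyond the scatter). The readings of compound 1 and compound 2 are limits of the assay, not numbers: the limit of > 10000 nM in this assay, at which 2 of the 4 values shown sit.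

The compounds shown leave open whether the double bond in the ring matters, and whether an amine nitrogen in place of the oxygen would give a similar reading. They also leave open how a longer open chain such as butyl, or a phenyl ring, would fare at this position.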